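Aryl-triazole esters of a triterpenoid: three limits, one forecast

The source may hold more compounds than are shown below. What is called first, only, known or untested is meant among the compounds shown, and "the series" means these compounds.

Compound 1, `C/C(=C\CC/C(C)=C/CC[C@@H]1[C@@]2(C)CCC(=O)C(C)(C)[C@H]2CC[C@@]1(C)O)CC/C=C(\C)C(=O)OCc1cn(-c2ccc(F)c(Cl)c2)nn1` — in a functional assay on A549 cells (Homo sapiens) for antiproliferative activity, read by MTT assay, with a stated time of 48 h (a higher number here means a weaker inhibitor, a lower number a stronger inhibitor), compound 1 gives only a limit, > 150000 nM
Compound 2, `COc1cccc(-n2cc(COC(=O)/C(C)=C/CC/C(C)=C/CC/C(C)=C/CC[C@@H]3[C@@]4(C)CCC(=O)C(C)(C)[C@H]4CC[C@@]3(C)O)nn2)c1` — in this assay compound 2 gives only a limit, > 150000 nM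
Compound 3, `C/C(=C\CC/C(C)=C/CC[C@@H]1[C@@]2(C)CCC(=O)C(C)(C)[C@H]2CC[C@@]1(C)O)CC/C=C(\C)C(=O)OCc1cn(-c2cccc(C(F)(F)F)c2)nn1` — in this assay compound 3 gives only a limit, > 150000 nM

Compound 1 stands nowhere readable on these numbers: its value in this assay is a limit, and the two companions show limits too, so no order among the three can be drawn. The measured steps are all unreadable for the same reason: a step that the two limits leave unreadable from compound 1 to compound 2, a step that the two limits leave unreadable from compound 1 to compound 3 and a step that the two limits leave unreadable from compound 2 to compound 3 each run from one limit to another. Within the data shown here, the one piece of evidence is the limit of > 150000 nM in this assay, at which 3 of the 3 values shown sit, which describes the whole set rather than any single change.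

Compound 4, `COc1ccc(-n2cc(COC(=O)/C(C)=C/CC/C(C)=C/CC/C(C)=C/CC[C@@H]3[C@@]4(C)CCC(=O)C(C)(C)[C@H]4CC[C@@]3(C)O)nn2)cc1`, is the next member of the series. It differs from compound 1 by 4-methoxyphenyl in place of 3-chloro-4-fluorophenyl on an aromatic nitrogen. Among the measured compounds shown here, the only step that bears on it is the unreadable change from the first to the second compound, where a methoxyphenyl also replaced the 3-chloro-4-fluorophenyl; its size could not be read. For the measured compounds named here, no step of readable size exists, so compound 4 is expected to return yet another limit rather than a number. The estimated step is then a step that the limit leaves unreadable from compound 1 to compound 4. Compound 4 is therefore estimated at 200000 nM, between 100000 nM and 600000 nM.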

Compound 4, half-maximal inhibitory concentration: > 150000 nM
Compound 4: only a limit was reported (the forecaster's own chance of this, stated with the estimate: 85%); the middle value is on the limit's open side.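

In this assay compound 4 gives > 150000 nM, which is a limit and not a number. None of its steps from compound 1, compound 2 and compound 3 can be read. The compounds shown leave open whether changing the aryl group on the aromatic nitrogen alters the activity at all: the limit of > 150000 nM in this assay, at which 4 of the 4 values shown sit.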